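Losing the bromo ring from compound 3

A few compounds are considered here, and "the series" means these few. Any claim that something is new, unique, unknown or untested is made for them only; others in the source may bear on it.

Measured so far in a functional assay on HCT-116 cells (Homo sapiens) for antiproliferative activity, read by MTT assay, with a stated time of 48 h; a lower number here means a stronger inhibitor, a higher number a weaker inhibitor
- compound 1 `COc1cc(N(Cc2ccccc2)C(=O)CSc2nc3ccccc3s2)cc(OC)c1OC` gives 54500 nM
- compound 2 `COc1ccc(CN(C(=O)CSc2nc3ccccc3s2)c2cc(OC)c(OC)c(OC)c2)cc1OC` gives 33900 nM
- compound 3 `COc1ccc(CN(C(=O)CSc2nc3ccccc3s2)c2cc(OC)c(OC)c(OC)c2)cc1Br` gives 4550 nM

Compound 3 stands lowest of the three in this assay, at 4550 nM. The unmeasured compound 4 `COc1cc(N(Cc2ccc(F)cc2)C(=O)CSc2nc3ccccc3s2)cc(OC)c1OC` differs from it as follows: 4-fluorophenyl in place of 3-bromo-4-methoxyphenyl on a saturated chain carbon bound to an amide-type nitrogen. That is, 4-fluorophenyl stands in place of 3-bromo-4-methoxyphenyl on a saturated chain carbon bound to an amide-type nitrogen.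

Among the measured compounds shown here, two measured steps bear most directly on this change. The large 12-fold lower number from compound 1 to compound 3 (1.08 log units; beyond the scatter) and the modest 7.5-fold lower number from compound 2 to compound 3 (0.87 log units; beyond the scatter) both end at the bromo compound. By contrast, a 1.6-fold lower number from compound 1 to compound 2 (0.21 log units; within the scatter) stays within the scatter. For the measured compounds named here, compound 4 has no bromo, so most of the distance to compound 3 should be given back, though no fluoro compound has yet been measured. A clear move to a higher number is expected, of the size a 6.6-fold higher number from compound 3 to compound 4 (0.82 log units; beyond the scatter). Compound 4 is estimated at 30000 nM, with an expected range of 10000 nM to 70000 nM.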

Compound 4, half-maximal inhibitory concentration: 59800 nM
Compound 4: the middle estimate sits 2.0-fold (0.30 log units) below what was measured; the measured number falls inside the stated range.
By their numbers in this assay, from the lowest: compound 3; then compounds 2, 1 and 4 (each within the scatter of the next).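

Read in this assay the exchange of 3-bromo-4-methoxyphenyl for 4-fluorophenyl gives a 13-fold higher number from compound 3 to compound 4 (1.12 log units; beyond the scatter) and so shows that compound 3's standing does not carry over to this fluoro ring. The fluoro brings no separation from the plain phenyl, with a 1.1-fold higher number from compound 1 to compound 4 (0.04 log units; within the scatter) as its step, or from the 3,4-dimethoxyphenyl, with a 1.8-fold higher number from compound 2 to compound 4 (0.25 log units; within the scatter) as its step, and both steps lie within the scatter. Among these four compounds only compound 3 stands apart at this position, and no measurement given here accounts for that.

Compound 3 is the only bromo compound shown, so it stays open whether a 3-bromophenyl without the methoxy would keep its number. From the compounds shown here alone, whether a chloro or a nitrile in the bromo's place would do the same also stays open.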